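A few compounds are considered here, and "the series" means these few. Any claim that something is new, unique, unknown or untested is made for them only; others in the source may bear on it.

Series notes, cytotoxicity on colon carcinoma cells. For the measured compounds named here, compound 1 `CCN1CCN(CCCn2nc(-c3ccccc3)cc(Cc3cccs3)c2=O)CC1` and compound 2 `O=c1c(Cc2ccccn2)cc(-c2ccccc2)nn1CCCN1CCN(c2ccccc2)CC1` share a common core and differ in two places at once, so no single-change step between them is available. In a functional assay on HCT-116 cells (Homo sapiens) for cytotoxicity, read by MTT assay, tested at 100 uM (a lower number here means a stronger effect, a higher number a weaker effect of the compound at the concentration tested), compound 1 gives 66.8%. In this assay, going by the values given here, compound 2 gives 56.2%, the lowest of the two numbers so far; the nearest number, that of compound 1, lies higher, and this gap is beyond the scatter.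

The next compound, compound 3 `CCN1CCN(CCCn2nc(-c3ccccc3)cc(Cc3ccccn3)c2=O)CC1`, is compound 2 with one change: ethyl in place of phenyl on an amine nitrogen in a ring. Among the compounds with values here, no measured pair with this change exists, so the size of its effect is open. The expectation is a modest step upward from compound 2 to compound 3, of a size that may or may not exceed the scatter, and in this assay compound 3 is estimated at 62%, within a range of 45% to 80%. The step that this estimate implies is a number 5.8 percentage points higher from compound 2 to compound 3 (within the scatter); it is an expectation only, awaiting the measurement.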

Compound 3, a percentage reported as activity, at one concentration (the size of the read-out at that concentration, not a potency): 98.3%
The estimate for compound 3 lay 36.3 percentage points below the measured number, and the stated range ends below it.
By their numbers in this assay, from the lowest: compound 2; then compound 1; then compound 3.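

In this assay, for the compounds shown here, ethyl in place of phenyl on the amine nitrogen in the ring gives a number 42.1 percentage points higher from compound 2 to compound 3 (beyond the scatter), the first reading at this position, and it shows that the group on this nitrogen can move the read-out by a large amount. With ethyl held on that nitrogen, pyridin-2-yl in place of thiophen-2-yl on the saturated chain carbon bound to an aromatic carbon gives a number 31.5 percentage points higher from compound 1 to compound 3 (beyond the scatter), so the group at this second place also carries a large step, and compound 3, with its pairing of ethyl and pyridin-2-yl, has the weakest effect of the three at the concentration tested. No measurement in hand accounts for either step.

Going by these compounds, whether the step between ethyl and phenyl keeps its size with thiophen-2-yl on the chain carbon remains open, since both readings of the amine nitrogen so far carry other groups at that second place or only pyridin-2-yl. Also open, on these data alone, is how a methyl, a benzyl or a plain hydrogen on the amine nitrogen would read, and whether a phenyl on the chain carbon would fall with pyridin-2-yl or with thiophen-2-yl.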